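Swapping Amino for Hydroxy on a Small Aromatic Ring

The source may report more compounds than this note shows. Statements on the series, on what has been measured and on what is new or still open speak of the compounds shown alone.

In an assay on isolated protein for inhibition of mitogen-activated protein kinase kinase kinase 14 (Homo sapiens), read by ADP-Glo, with a stated time of 60 min, tested at 100 uM, in the presence of a further agent that is not named here (a higher number here means more inhibition at the concentration tested (going by the name of the read-out), a lower number less inhibition), the three measured compounds give the following numbers:

compound 1 `Cn1nc(O)c(C(=O)Nc2cc(C(F)(F)F)cc(C(F)(F)F)c2)n1`: 9.1%
compound 2 `O=C(Nc1cc(C(F)(F)F)cc(C(F)(F)F)c1)c1n[nH]nc1O`: -9.5%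
compound 3 `Nc1nonc1C(=O)Nc1cc(C(F)(F)F)cc(C(F)(F)F)c1`: -9.2%

Compound 3 stands second highest of the three. Its number sits within the usual scatter of compound 2, so the two cannot be told apart, while compound 1 lies beyond the scatter above it. Compound 4 `O=C(Nc1cc(C(F)(F)F)cc(C(F)(F)F)c1)c1nonc1O` differs from compound 3 by hydroxy in place of amino on an aromatic carbon.

Going by the values given here, no measured step makes exactly this exchange. The closest guide is the step from compound 2 to compound 3, which replaces a hydroxy-bearing five-membered ring with the amino-bearing one: a number 0.3 percentage points higher from compound 2 to compound 3 (within the scatter). The step of a number 18.6 percentage points lower from compound 1 to compound 2 (beyond the scatter) concerns a methyl on a ring nitrogen and says little here. Given that the hydroxy and amino rings of compound 2 and compound 3 gave the same reading in this assay, the expected step is none beyond the scatter: a number 2.2 percentage points higher from compound 3 to compound 4 (within the scatter). Compound 4 is therefore estimated at -7%, with a range from -25% to 12%.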

Compound 4, a percentage reported as inhibition, at one concentration (the size of the read-out at that concentration, not a potency): 19.3%
Compound 4: the middle estimate sits 26.3 percentage points below what was measured; the whole stated range lies below it.
By their numbers in this assay, from the lowest: compounds 2 and 3 (each within the scatter of the next); then compound 1; then compound 4.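

The aromatic carbon on this five-membered ring with 2 nitrogen and 1 oxygen responds to the exchange of a single atom: hydroxy and amino carry the same counts of hydrogen-bond donors and acceptors, yet hydroxy in place of amino gives a number 28.5 percentage points higher from compound 3 to compound 4 (beyond the scatter) in this assay. A hydroxy group does not bring this reading on every ring, as 4-hydroxy-1,2,5-oxadiazol-3-yl in place of 5-hydroxy-2H-1,2,3-triazol-4-yl gives a number 28.8 percentage points higher from compound 2 to compound 4 (beyond the scatter), and in place of 5-hydroxy-2-methyl-2H-1,2,3-triazol-4-yl gives a number 10.2 percentage points higher from compound 1 to compound 4 (beyond the scatter). Nothing available offers an explanation for these steps.

On these data alone, it remains open how a methoxy group or a carboxylic acid on this same carbon would read. All these readings also come from a single concentration, so they leave the potency of compound 4 unsettled.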